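The source may hold more compounds than are shown below. What is called first, only, known or untested is meant among the compounds shown, and "the series" means these compounds.

In an ADME assay on microsomes from liver (Homo sapiens) for metabolic stability, using NADPH, with a stated time of 10 min (on this read-out higher numbers stand for a more stable compound and lower numbers for a less stable compound), three compounds built on a shared core have been measured so far. Compound 1 (`NCCCCN(C[C@H]1Cc2ncccc2CN1)[C@H]1CCCc2cccnc21`) gives 100% and compound 2 (`CN(C[C@H]1Cc2ncccc2CN1)[C@H]1CCCc2cccnc21`) gives 95% while compound 3 (`CCN(CC)CCCCN(C[C@H]1Cc2ncccc2CN1)[C@H]1CCCc2cccnc21`) gives 80% and is the lowest of the three. Compound 4 (`c1cnc2c(c1)CN[C@@H](CN(CCCCNC1CCOCC1)[C@H]1CCCc3cccnc31)C2`) is still unmeasured and differs from compound 3 by a single change ((oxan-4-yl)amino in place of diethylamino on a saturated chain carbon, four bonds along the chain from an amine nitrogen) with (oxan-4-yl)amino in place of diethylamino on a saturated chain carbon, four bonds along the chain from an amine nitrogen.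

Among the measured compounds shown here, two measured steps bear on this place. Diethylamino in place of amino gave a number 20 percentage points lower from compound 1 to compound 3 (beyond the scatter) and adding the whole 3-(diethylamino)propyl chain gave a number 15 percentage points lower from compound 2 to compound 3 (beyond the scatter) as the other modest step. Hydrogen in place of 3-aminopropyl gave a number 5 percentage points lower from compound 1 to compound 2 (within the scatter) as a step of no clear size. For the measured compounds named here, no measured compound carries the (oxan-4-yl)amino group, so these steps set only a rough scale. An estimated a number 5 percentage points higher from compound 3 to compound 4 (within the scatter) is therefore expected, a small upward move. For compound 4 the estimated value is 85% (65% to 100% as the expected range).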

Compound 4, percent of the compound remaining: 97%
Compound 4: the middle estimate sits 12 percentage points below what was measured; low and high end bracket the measured number.
By their numbers in this assay, from the lowest: compound 3; then compounds 2, 4 and 1 (each within the scatter of the next).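

In this assay, (oxan-4-yl)amino in place of diethylamino on the saturated chain carbon, four bonds along the chain from an amine nitrogen, gives a number 17 percentage points higher from compound 3 to compound 4 (beyond the scatter) and so shows that the drop seen with diethylamino is not shared by every substituted amine at this place. The whole chain can also be present without a readable loss: 3-((oxan-4-yl)amino)propyl in place of hydrogen gives a number 2 percentage points higher from compound 2 to compound 4 (within the scatter) and oxan-4-yl in place of hydrogen on the amine nitrogen gives a number 3 percentage points lower from compound 1 to compound 4 (within the scatter) in the same assay. Nothing shown here explains the gap between diethylamino and (oxan-4-yl)amino.

The new group differs from diethylamino in its ring, its oxygen and the hydrogen on its nitrogen, and these compounds do not separate the three. A cyclohexylamino group would remove only the ring oxygen, while a dimethylamino group would show how a smaller amine without a ring behaves at this place.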